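A bicyclic heteroaromatic ring in place of phenyl

The source may report more compounds than this note shows. Statements on the series, on what has been measured and on what is new or still open speak of the compounds shown alone.

compound 1 `O=C(O)CCCSCCN1C(=O)CC[C@@H]1/C=C/[C@@H](O)Cc1cccc(N2Cc3ccccc3C2)c1`: 4.4 nM
compound 2 `O=C(O)CCCSCCN1C(=O)CC[C@@H]1/C=C/[C@@H](O)Cc1cccc(-c2ccc3[nH]ccc3c2)c1`: 0.28 nM
compound 3 `O=C(O)c1csc(SCCN2C(=O)CC[C@@H]2/C=C/[C@@H](O)Cc2cccc(-c3ccccc3)c2)n1`: 0.94 nM

All three compounds were measured in an assay on CHO cells for displacement of a labelled ligand from prostaglandin E2 receptor EP4 subtype (Mus musculus), read by scintillation counting, with a stated time of 60 min; on this read-out higher numbers stand for weaker inhibition and lower numbers for stronger inhibition. Compound 3 holds the second highest number of the three: compound 2 gives a lower number, compound 1 a higher one, and both gaps lie beyond the scatter.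

Compound 4 `Cc1ccc2oc(-c3cccc(C[C@H](O)/C=C/[C@H]4CCC(=O)N4CCSc4nc(C(=O)O)cs4)c3)nc2c1` differs from compound 3 in one place: 5-methyl-1,3-benzoxazol-2-yl in place of phenyl on an aromatic carbon. Among the compounds with values here, the one measured step, a 16-fold lower number from compound 1 to compound 2 (1.20 log units; beyond the scatter), put an aromatic bicycle in place of a non-aromatic bicycle on the same aromatic carbon, and bears on the present change only in part, since here a bicyclic aromatic ring replaces a single phenyl ring. Within the data shown here, compound 2, which carries an aromatic bicycle at that position, gives a lower number than compound 3 with its phenyl, but these two compounds differ elsewhere as well, so no clean step can be drawn from them. Taken together, a moderate move toward a lower number seems the most likely outcome, with wide uncertainty in either direction.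

Compound 4 is therefore expected to give about 0.5 nM, within 0.1 nM to 2.5 nM. The step this estimate implies is a 1.9-fold lower number from compound 3 to compound 4 (0.27 log units; within the scatter).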

Compound 4, inhibition constant: 0.21 nM
Compound 4: the middle estimate sits 2.4-fold (0.38 log units) above what was measured, within the range that was stated.
By their numbers in this assay, from the lowest: compounds 4 and 2 (each within the scatter of the next); then compound 3; then compound 1.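

In this assay, putting 5-methyl-1,3-benzoxazol-2-yl in place of phenyl gives a 4.5-fold lower number from compound 3 to compound 4 (0.65 log units; beyond the scatter). The two compounds differ in this one place, and the step can be read directly. The earlier step compared two bicycles on a different core, one aromatic and one not, whereas this one shows that on this aromatic carbon a larger aromatic bicycle with 10 heavy atoms and 2 hydrogen-bond acceptors gives a lower number than a single phenyl ring. No measurement available here explains why the number falls, so the gain cannot be assigned to the second ring, the methyl, or the ring nitrogen and oxygen.

On these data alone, it remains open what the methyl itself contributes, which a comparison of compound 4 with the unsubstituted 1,3-benzoxazol-2-yl analogue, or with a chlorine or methoxy group in place of the methyl, could show. As far as these compounds go, it is also open whether 5-methyl-1,3-benzoxazol-2-yl would lower the number to a similar extent on the core of compound 2, or whether an amine on the bicycle would be accepted at this position.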